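The source may report more compounds than this note shows. Statements on the series, on what has been measured and on what is new or still open speak of the compounds shown alone.

Measured in a functional assay on RAW264.7 cells (Mus musculus) for inhibition, read by Griess assay, with stated times of 2 h and 18 h; on this read-out higher numbers stand for weaker inhibition and lower numbers for stronger inhibition:
- Compound 1 `CC1=C(CCc2ccoc2)[C@@]2(C)CC[C@@H](O)C(C)(C)[C@@H]2[C@H](O)C1=O`: > 50000 nM (a limit)
- Compound 2 `CC(=O)O[C@@H]1CC[C@]2(C)C(CCc3ccoc3)=C(C)C(=O)[C@@H](O)[C@H]2C1(C)C`: 22500 nM
- Compound 3 `CC1=C(CCc2ccoc2)[C@@]2(C)CCCC(C)(C)[C@@H]2[C@H](O)C1=O`: > 50000 nM (a limit)

In this assay, compound 3 has only a limit, > 50000 nM. That is the limit of > 50000 nM in this assay, at which 2 of the 3 values shown sit. Compound 4 `COC1CC(O)(CCC2=C(C)C(=O)[C@@H](O)[C@H]3C(C)(C)CCC[C@]23C)CO1` carries 3-hydroxy-5-methoxyoxolan-3-yl in place of furan-3-yl on a saturated chain carbon, two bonds along the chain from a double-bonded ring carbon.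

The measured steps all change a saturated ring carbon instead: an at least 2.2-fold lower number from compound 1 to compound 2 (0.34 log units; beyond the scatter), an at least 2.2-fold higher number from compound 2 to compound 3 (0.34 log units; beyond the scatter) and a step that the two limits leave unreadable from compound 1 to compound 3. None touches the furan-3-yl, so they set no size for this change. Only a small step, if any, toward lower numbers is expected: an at least 1.2-fold lower number from compound 3 to compound 4 (0.09 log units; that floor lies within the scatter). For compound 4 the estimate is 40000 nM, with an expected range of 15000 nM to 80000 nM.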

Compound 4, half-maximal inhibitory concentration: 26400 nM
Compound 4: the middle estimate sits 1.5-fold (0.18 log units) above what was measured; measured number inside the range.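

For the compounds shown here, this is the first change away from the saturated ring carbon, and in this assay it gives an at least 1.8-fold lower number from compound 3 to compound 4 (0.27 log units; that floor lies within the scatter). Compound 3 stands only at a limit of the assay: the limit of > 50000 nM in this assay, at which 2 of the 4 values shown sit.

Compound 4 does give a measured number, so the furan-3-yl can be exchanged for this larger non-aromatic ring without the read-out staying at that limit, although the true size of the step remains unsettled. The compounds shown leave open whether the hydroxy or the methoxy on the new ring accounts for the step. As far as these compounds go, how an amine or a carboxylic acid would read at this place also stays open.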